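The source may report more compounds than this note shows. Statements on the series, on what has been measured and on what is new or still open speak of the compounds shown alone.

Measured compounds in an assay (Cricetulus griseus) for inhibition of aldehyde dehydrogenase, mitochondrial (Homo sapiens); on this read-out higher numbers stand for weaker inhibition and lower numbers for stronger inhibition:
Compound 1 `NCCCCCCOc1ccc2c(=O)c(-c3ccc(O)cc3)coc2c1` gives 100 nM.
Compound 2 `CCOC(=O)CCCCCOc1ccc2c(=O)c(-c3ccc(O)cc3)coc2c1` gives 280 nM.
Compound 3 `C=CCCCCOc1ccc2c(=O)c(-c3ccc(O)cc3)coc2c1` gives 150 nM.

Compound 3 sits second highest of the three numbers; its step from compound 1 is a 1.5-fold higher number from compound 1 to compound 3 (0.18 log units; within the scatter), and its step from compound 2 is a 1.9-fold lower number from compound 2 to compound 3 (0.27 log units; within the scatter), so all three lie within the scatter of one another. Compound 4 `O=c1c(-c2ccc(O)cc2)coc2cc(OCCCCCCCCCCCCO)ccc12` differs from compound 3 by 8-hydroxyoctyl in place of vinyl on a saturated chain carbon, four bonds along the chain from an oxygen on an aromatic ring. Among the compounds with values here, the two steps that bear on it, a 1.5-fold higher number from compound 1 to compound 3 (0.18 log units; within the scatter) and a 1.9-fold lower number from compound 2 to compound 3 (0.27 log units; within the scatter), show that swapping the chain end between vinyl, amine and ester changed little; the far longer hydroxyl-bearing chain has no precedent here. Compound 4 is therefore expected to give about 200 nM in this assay, between 60 nM and 700 nM, an estimated step of a 1.3-fold higher number from compound 3 to compound 4 (0.12 log units; within the scatter).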

Compound 4, half-maximal inhibitory concentration: 1700 nM
For compound 4 the middle estimate is 8.5-fold (0.93 log units) below the measured one, and the stated range ends below it.
By their numbers in this assay, from the lowest: compounds 1, 3 and 2 (each within the scatter of the next, the first and the last beyond it); then compound 4.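

In this assay, the chain end on this saturated chain proves not to be freely variable: 8-hydroxyoctyl in place of vinyl gives an 11-fold higher number from compound 3 to compound 4 (1.05 log units; beyond the scatter) and so departs far more than the earlier swaps did. The same separation appears in a 6.1-fold higher number from compound 2 to compound 4 (0.78 log units; beyond the scatter) and in a 17-fold higher number from compound 1 to compound 4 (1.23 log units; beyond the scatter) so compound 4 stands apart from all three earlier compounds.

Chain length and the terminal hydroxyl change together here, so an unsubstituted alkyl chain of the same length or a shorter chain ending in hydroxyl would be needed to tell them apart. Nothing available accounts for the loss.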